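Bromo on the fused benzene ring of compound 2

This account rests on a few compounds, and the source may have more. Where it says the series, first, only, none or still open, it means among the compounds named here.

Among the measured compounds shown here, compound 2 `N#CC1=C(N)Oc2cc3oc(-c4ccccc4)cc(=O)c3c(O)c2C12C(=O)Nc1ccccc12` is the only member of the series with an actual number in a functional assay on A549 cells (Homo sapiens) for antiproliferative activity, read by MTT assay, with a stated time of 48 h (a lower number here means a stronger inhibitor, a higher number a weaker inhibitor), where compound 2 gives 37600 nM. Compound 1 `CC(C)(C)OC(=O)CN1C(=O)C2(C(C#N)=C(N)Oc3cc4oc(-c5ccccc5)cc(=O)c4c(O)c32)c2ccccc21` carries a (tert-butoxycarbonyl)methyl group on the amide-type nitrogen in the ring; in this assay compound 1 reaches only the limit > 50000 nM. Compound 3 `N#CC1=C(N)Oc2cc3oc(-c4ccccc4)cc(=O)c3c(O)c2C12C(=O)Nc1c(Cl)cccc12` bears chloro on an aromatic carbon; in this assay compound 3 likewise reaches only the limit > 50000 nM. Both measured steps are therefore floors: an at least 1.3-fold lower number from compound 1 to compound 2 (0.12 log units; that floor lies within the scatter) and an at least 1.3-fold higher number from compound 2 to compound 3 (0.12 log units; that floor lies within the scatter). Each floor lies within the scatter, so neither step is shown to be beyond it, and the limit of > 50000 nM in this assay, at which 2 of the 3 values shown sit, marks the ceiling of what this assay can resolve.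

Compound 4 `N#CC1=C(N)Oc2cc3oc(-c4ccccc4)cc(=O)c3c(O)c2C12C(=O)Nc1cc(Br)ccc12` differs from compound 2 by bromo in place of hydrogen on an aromatic carbon. The step to compound 3 is the one that bears on it: chloro in place of hydrogen on an aromatic carbon, which in this assay carried the number up to the limit. For compound 4 the same direction is expected, a step of a 1.3-fold higher number from compound 2 to compound 4 (0.12 log units; within the scatter), with a fair chance that only a limit is reported. The estimate for compound 4 in this assay is 50000 nM, within 20000 nM to 120000 nM.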

Compound 4, half-maximal inhibitory concentration: 9340 nM
Compound 4: middle estimate off by 5.4-fold (0.73 log units), on the high side; measured number below the stated range.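

Bromo in place of hydrogen on this aromatic carbon, meta to a fused ring and para to a fused ring, gives the first step in the series that can be read as beyond the scatter in this assay, with a 4.0-fold lower number from compound 2 to compound 4 (0.60 log units; beyond the scatter). The earlier steps shown here were floors within the scatter, so they could not show that any single change on the shared core moves the number; this one shows that a change at this position can lower it, though only modestly. Compound 4 also stands clear of the limit reached by compound 1 and compound 3, whose steps cannot be sized: the limit of > 50000 nM in this assay, at which 2 of the 4 values shown sit.

Compound 3 carries chloro rather than bromo, and on another aromatic carbon, so it differs from compound 4 in more than one place and does not show whether the lower number belongs to bromo or to halogens in general at this position. Fluoro, methyl, methoxy or an amine on the same carbon would test that, and the compounds shown give no measured property that could explain the step.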